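The compounds below may be only part of what the source reports. "The series", "measured", "known", "first", "only" and "open" are said of these compounds alone.

The account concerns two ureas on a shared core and a third compound not yet tested. Compound 1 `CC(=O)c1ccc(NC(=O)Nc2cc(C)nc3ccccc23)cc1` carries an acetyl group on its pendant aromatic ring. In an ADME assay on HEK293 cells (Homo sapiens) for cytotoxicity, with a stated time of 72 h (a higher number here means that more compound is needed for the effect, a lower number that less compound is needed), compound 1 reaches only > 25000 nM, which is a limit of the assay rather than a number. Compound 2 `Cc1cc(NC(=O)Nc2ccc([N+](=O)[O-])c(C(F)(F)F)c2)c2ccccc2n1` differs from compound 1 on its other ring, carrying nitro and trifluoromethyl groups. In this assay compound 2 likewise stops at > 25000 nM, again a limit and not a number. Compound 1 thus stands at the limit of > 25000 nM in this assay, at which 2 of the 2 values shown sit, with no number to rank it against any other compound. Compound 3 `COc1ccc(NC(=O)Nc2cc(C)nc3ccccc23)cc1` is the compound still to be measured; it differs from compound 1 by methoxy in place of acetyl on an aromatic carbon, placed on an aromatic carbon of a six-membered aromatic ring of carbon only, para to a large group. Going by the values given here, no step between measured compounds exists to guide the size of this change. Because compound 1 sits at the limit of > 25000 nM in this assay, at which 2 of the 2 values shown sit, the step is expected to be a step that the limit leaves unreadable from compound 1 to compound 3, nothing beyond the scatter. Compound 3 is accordingly expected to give 30000 nM, within 15000 nM to 60000 nM, most likely again as a limit.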

Compound 3, half-maximal effective concentration: > 25000 nM
Compound 3 gave a limit, no number; the forecaster's own chance of this, stated with the estimate: 80%; the middle value is on the limit's open side.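

In this assay compound 3 gives > 25000 nM, which is a limit and not a number. Going by these compounds alone, no step from compound 1 to compound 3 can be read, because both stop at a limit: the limit of > 25000 nM in this assay, at which 3 of the 3 values shown sit. The compounds shown leave open whether methoxy and acetyl differ at all in this assay, and what number any of these three ureas would reach there.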